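The compounds below may be only part of what the source reports. "The series", "measured", "known", "first", "only" and "open" are said of these compounds alone.

Three compounds share one core and differ only in the aromatic group attached to it. Compound 1 `CCOc1ccc(-c2ccc3ncn(-c4cc(OC)c(OC)c(OC)c4)c3c2)cc1`, carrying a 4-ethoxyphenyl group, gives 1710 nM in a functional assay on MCF7 cells (Homo sapiens) for antiproliferative activity, read by MTT assay, with a stated time of 72 h; a higher number here means a weaker inhibitor, a lower number a stronger inhibitor. Compound 2 `COc1cc(-n2cnc3ccc(-c4cc(F)ccc4F)cc32)cc(OC)c1OC`, with a 2,5-difluorophenyl group, gives 6420 nM, and compound 3 `COc1cc(-n2cnc3ccc(-c4ccc(C)cc4)cc32)cc(OC)c1OC`, with a 4-methylphenyl group, gives 110 nM. Among these three, compound 2 has the highest number, so it is the weakest inhibitor here: one gap is a 3.8-fold higher number from compound 1 to compound 2 (0.57 log units; beyond the scatter), and the other is a 58-fold lower number from compound 2 to compound 3 (1.77 log units; beyond the scatter). Exchanging the ethoxy of compound 1 for a methyl gives a 16-fold lower number from compound 1 to compound 3 (1.19 log units; beyond the scatter).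

Compound 4 `COc1cccc(-c2ccc3ncn(-c4cc(OC)c(OC)c(OC)c4)c3c2)c1` is not yet measured. It differs from compound 2 in one place: 3-methoxyphenyl in place of 2,5-difluorophenyl on an aromatic carbon. Both measured steps away from compound 2 lead to lower numbers, one modest and one large, so replacing the 2,5-difluorophenyl group is expected to lower the number again. The entering 3-methoxyphenyl group resembles the 4-ethoxyphenyl of compound 1 more than the 4-methylphenyl of compound 3 in that both carry an alkoxy oxygen, so a step nearer the modest one seems the likelier outcome. Compound 4 is therefore estimated at 1000 nM, with a plausible range from 200 nM to 5000 nM. That estimate corresponds to an expected step of a 6.4-fold lower number from compound 2 to compound 4 (0.81 log units; beyond the scatter).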

Compound 4, half-maximal inhibitory concentration: 1610 nM
Compound 4: middle estimate off by 1.6-fold (0.21 log units), on the low side; the measured number falls inside the stated range.
By their numbers in this assay, from the lowest: compound 3; then compounds 4 and 1 (each within the scatter of the next); then compound 2.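

In this assay, the step of a 4.0-fold lower number from compound 2 to compound 4 (0.60 log units; beyond the scatter) shows a third replacement of the 2,5-difluorophenyl group also lowering the number, so the lowering seen earlier is not tied to only the 4-ethoxyphenyl and 4-methylphenyl groups. The step of a 1.1-fold lower number from compound 1 to compound 4 (0.03 log units; within the scatter) lies within the scatter, so the 3-methoxyphenyl and 4-ethoxyphenyl groups cannot be told apart in this assay, even though they differ both in the length of the oxygen-linked chain and in where it sits on the ring. The step of a 15-fold higher number from compound 3 to compound 4 (1.17 log units; beyond the scatter) is large, which leaves compound 3 clearly apart from both oxygen-bearing compounds and shows that a single change of aromatic group at this carbon can shift the number substantially.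

Nothing available here explains why these groups differ, as no separate measurement bears on the result. On these data alone, it remains open whether the gap to compound 3 follows from the methyl group itself or from its place on the ring, a question that 4-methoxyphenyl and 3-methylphenyl groups could help settle, and how an aminophenyl or carboxyphenyl group would behave at this carbon is also unknown.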